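Pyridine in Place of a Halogenated Phenyl on a Dopamine Receptor Agonist

The compounds below may be only part of what the source reports. "The series", "measured", "known", "first", "only" and "open" are said of these compounds alone.

Measured so far:
compound 1, `Cc1cccc(C(=O)NCN2CCC(c3nccs3)CC2)c1`: 9.8 nM
compound 2, `O=C(NCN1CCC(c2cccc[n+]2[O-])CC1)c1ccc(F)c(Cl)c1`: 63 nM

Of the compounds shown here, two have been measured in a functional assay on HEK293 cells for agonist activity at D(4) dopamine receptor (Homo sapiens), read by FLIPR; on this read-out lower numbers stand for an effect already at smaller amounts and higher numbers for an effect only at larger amounts of compound. Compound 1 gives 9.8 nM in this assay. Compound 2 gives 63 nM in this assay, the higher of the two numbers; its gap to compound 1 lies beyond the usual scatter of repeated measurements, so compound 2 is the weaker agonist of the pair. The two compounds differ in more than one place, so no single change can be tied to that gap.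

Compound 3, `O=C(NCN1CCC(c2cccc[n+]2[O-])CC1)c1ccccn1`, has not yet been measured. It keeps the core of compound 2 and differs from it in one spot: pyridin-2-yl in place of 3-chloro-4-fluorophenyl on a carbonyl carbon. For the measured compounds named here, no step between measured compounds shows what this exchange does, so the expectation for compound 3 rests on the number for compound 2 alone.

Compound 3 is expected to stay near compound 2 in this assay, with a step of a 1.6-fold higher number from compound 2 to compound 3 (0.20 log units; within the scatter) that could fall on either side of the scatter. The estimated value for compound 3 is 100 nM, within a range from 25 nM to 400 nM.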

Compound 3, half-maximal effective concentration: 3150 nM
Compound 3: middle estimate off by 32-fold (1.50 log units), on the low side; the whole stated range lies below it.
By their numbers in this assay, from the lowest: compound 1; then compound 2; then compound 3.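

For the compounds shown here, this is the first step that can be read at a single place, and it shows that agonist activity in this assay is highly sensitive to the group on this carbonyl carbon: pyridin-2-yl in place of 3-chloro-4-fluorophenyl gives a 50-fold higher number from compound 2 to compound 3 (1.70 log units; beyond the scatter). The exchange is modest by count, as a group of 8 heavy atoms leaves and one of 6 heavy atoms with 1 hydrogen-bond acceptor enters. Both groups are six-membered aromatic rings, yet having such a ring at this place does not by itself keep the activity of compound 2. Nothing measured here accounts for the size of the step.

The exchange removes the chlorine and the fluorine and brings in the ring nitrogen in one move, so compound 2 and compound 3 cannot show how much of the step belongs to each of these changes. An unsubstituted phenyl or a phenyl carrying chlorine alone on the same carbonyl carbon would begin to separate them, but the compounds shown leave that question open.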